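Adding a Second Chloro to the Weakest Compound

The compounds below may be only part of what the source reports. "The series", "measured", "known", "first", "only" and "open" are said of these compounds alone.

Compound 1, `O=C(c1cccnc1)c1ccccc1O`: 33000 nM
Compound 2, `C=CCOc1c(Cl)cccc1C(=O)c1cccnc1`: 100000 nM
Compound 3, `Cc1ccc(O)c(C(=O)c2cccnc2)c1`: 26000 nM

Of the compounds shown here, three have been measured in a functional assay on HeLa cells (Homo sapiens) for cytotoxicity, read by sulforhodamine B assay, with a stated time of 48 h; on this read-out higher numbers stand for weaker inhibition and lower numbers for stronger inhibition. Compound 2 stands highest of the three, and its distance to each of the other two lies beyond the usual scatter, so on these numbers it is the weakest inhibitor of cell growth. Compound 1 and compound 3 sit close together: the step of a 1.3-fold lower number from compound 1 to compound 3 (0.10 log units; within the scatter) is within the scatter.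

Compound 4, `C=CCOc1c(Cl)cc(Cl)cc1C(=O)c1cccnc1`, is the next compound to be measured. It differs from compound 2 by chloro in place of hydrogen on an aromatic carbon. Among the compounds with values here, the one measured step, from compound 1 to compound 3, concerns a methyl entering on a different core and gives no guidance on a chloro entering; no measured pair involves a second chloro at all. With nothing to point either way, the expectation is a step of about a 1.3-fold lower number from compound 2 to compound 4 (0.10 log units; within the scatter) in this assay, that is, no change beyond the scatter. The estimated value for compound 4 is 80000 nM, expected to fall between 30000 nM and 200000 nM.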

Compound 4, half-maximal inhibitory concentration: 34000 nM
The estimate for compound 4 lay 2.4-fold (0.37 log units) above the measured number, within the range that was stated.
By their numbers in this assay, from the lowest: compounds 3, 1 and 4 (each within the scatter of the next); then compound 2.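

On the ring that carries the allyloxy group, the position para to that group and meta to the chloro group already present is not a silent one: chloro in place of hydrogen there gives a 2.9-fold lower number from compound 2 to compound 4 (0.47 log units; beyond the scatter) in this assay. Within the data shown here, this is the first step to lie beyond the scatter, so it is the first sign that a single new atom on an aromatic carbon can move this read-out, here towards stronger inhibition, although the step is only modest and rests on one pair of compounds. Nothing available explains why this one added chlorine atom lowers the number.

Whether this position responds to chloro alone remains open, since the compounds shown say nothing about how a fluoro, a bromo or an amine would behave in the same place. From the compounds shown here alone, it is also open whether the step depends on its surroundings, that is, whether the same chloro would matter as much with a free hydroxy group in place of the allyloxy group or without the first chloro group.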